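Carboxypyridinyl amine replacing trifluoromethylpyridinyl amine: solubility outlook

This account rests on a few compounds, and the source may have more. Where it says the series, first, only, none or still open, it means among the compounds named here.

Measured so far:
compound 1 `COc1ccc(Nc2cc3[nH]c(-c4cccc(C(F)(F)F)c4)nc3cn2)nc1` — < 5000 nM
compound 2 `FC(F)(F)c1cccc(-c2nc3cnc(Nc4cnccn4)cc3[nH]2)c1` — 155000 nM
compound 3 `FC(F)(F)c1ccc(Nc2cc3[nH]c(-c4cccc(C(F)(F)F)c4)nc3cn2)nc1` — < 5000 nM

In a physicochemical assay for solubility, using the shake flask method, measured as kinetic solubility, with a stated time of 20 h, at pH 2 (on this read-out higher numbers stand for higher solubility and lower numbers for lower solubility), compound 3 gives < 5000 nM, which is a limit of the assay and not a number. The same holds (the limit of < 5000 nM in this assay, at which 2 of the 3 values shown sit), so compound 3 stands at the bottom edge of what the three compounds show. Compound 4 `O=C(O)c1ccnc(Nc2cc3[nH]c(-c4cccc(C(F)(F)F)c4)nc3cn2)c1` differs from compound 3 by 4-carboxypyridin-2-yl in place of 5-(trifluoromethyl)pyridin-2-yl on a nitrogen on an aromatic ring. The step that bears on this change is an at least 31-fold lower number from compound 2 to compound 3 (1.49 log units; beyond the scatter), while a step that the two limits leave unreadable from compound 1 to compound 3 cannot be read because both ends are limits. Both earlier changes at this nitrogen moved the read-out by a large amount or left it at the limit; the direction for a carboxypyridinyl is not fixed by these data. A rise out of the limit is expected for compound 4, an at least 4.0-fold higher number from compound 3 to compound 4 (0.60 log units; beyond the scatter), with wide uncertainty. Compound 4 is estimated at 20000 nM, between 3000 nM and 150000 nM.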

Compound 4, solubility: < 5000 nM
Compound 4 ended at the assay's limit; the forecaster's own chance of this, stated with the estimate: 35%; middle value at least 4.0-fold (0.60 log units) away from the limit.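

Compound 4, with 4-carboxypyridin-2-yl on this nitrogen, gives a limit and not a number in this assay, and it joins the two other pyridinyl compounds there: the limit of < 5000 nM in this assay, at which 3 of the 4 values shown sit. Compound 2 goes against this pattern, with its pyrazin-2-yl, and shows an at least 31-fold lower number from compound 2 to compound 4 (1.49 log units; beyond the scatter). The steps from compound 1 and compound 3 to compound 4 have limits at both ends and cannot be read.

On these data alone, how far compound 1, compound 3 and compound 4 lie apart under the limit stays open. As far as these compounds go, whether an amine in place of the carboxy group would leave the limit also stays open.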